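The source may hold more compounds than are shown below. What is called first, only, known or untested is meant among the compounds shown, and "the series" means these compounds.

Values in a functional assay on A549 cells (Homo sapiens) for antiproliferative activity; a lower number here means a stronger inhibitor, a higher number a weaker inhibitor:
- compound 1 `CC(C)=CCCC1=CC[C@H](C(=O)Nc2ccc(O)cc2)[C@@H](c2ccccc2)C1` gives 66800 nM
- compound 2 `COC(=O)CCNC(=O)[C@H]1CC=C(CCC=C(C)C)C[C@@H]1c1ccccc1` gives 87900 nM

For the measured compounds named here, compound 2 stands level with the only other measured compound, within the scatter. Compound 3 `CON(C)C(=O)[C@H]1CC=C(CCC=C(C)C)C[C@@H]1c1ccccc1` is still unmeasured and differs from compound 2 by methoxy(methyl)amino in place of (2-(methoxycarbonyl)ethyl)amino on a carbonyl carbon. Going by the values given here, one measured step bears on this, also an exchange on the amide-type nitrogen: a 1.3-fold higher number from compound 1 to compound 2 (0.12 log units; within the scatter). On that single precedent, no change beyond the scatter is expected in this assay. The expected step is a 1.1-fold lower number from compound 2 to compound 3 (0.04 log units; within the scatter). For compound 3 the estimate is 80000 nM, with an expected range of 35000 nM to 170000 nM.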

Compound 3, half-maximal inhibitory concentration: 31200 nM
Compound 3: middle estimate off by 2.6-fold (0.41 log units), on the high side; the whole stated range lies above it.
By their numbers in this assay, from the lowest: compound 3; then compounds 1 and 2 (each within the scatter of the next).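

On a carbonyl carbon, methoxy(methyl)amino gives a change beyond the scatter in this assay from either secondary amide (a 2.8-fold lower number from compound 2 to compound 3 (0.45 log units; beyond the scatter); a 2.1-fold lower number from compound 1 to compound 3 (0.33 log units; beyond the scatter)). The position therefore responds to the amide substituent, which the exchange between compound 1 and compound 2 alone did not show. No measurement here accounts for the shift.

Still open, from the compounds shown here alone, is whether the change follows loss of the amide hydrogen or the methoxy group itself. A dimethylamino amide or a morpholine amide on the same carbonyl carbon would bear on this.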